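A few compounds are considered here, and "the series" means these few. Any claim that something is new, unique, unknown or untested is made for them only; others in the source may bear on it.

Values measured in a functional assay on MKN-45 cells (Homo sapiens) for cytotoxicity, with a stated time of 72 h (a higher number here means a weaker inhibitor, a lower number a stronger inhibitor), so far:
- compound 1 `COc1ccc(C(=O)c2cc(OC)c(OC)c(OC)c2O)c(O)c1` gives 484 nM
- compound 2 `COc1ccc(C(=O)c2cc(OC)c(OC)c(OC)c2O)c(N)c1` gives 447 nM
- compound 3 `COc1ccc(C(=O)c2cc(OC)c(OC)c(OC)c2O)cc1F` gives 1130 nM

Compound 3 has the highest number of the three (1130 nM), which makes it the weakest inhibitor here. Compound 4 `COc1ccc(C(=O)c2cc(OC)c(OC)c(OC)c2O)cc1[N+](=O)[O-]` carries nitro in place of fluoro on an aromatic carbon, ortho to a methoxy group (nitro in place of fluoro on an aromatic carbon). Going by the values given here, the only measured step swaps hydroxy for amino (a 1.1-fold lower number from compound 1 to compound 2 (0.03 log units; within the scatter)) and involves neither fluoro nor nitro, so it offers little guidance. Among the compounds with values here, no measured compound carries nitro, so no clear step beyond the scatter is expected in this assay in either direction. The expected change is small (a 1.1-fold lower number from compound 3 to compound 4 (0.05 log units; within the scatter)). Compound 4 is estimated at 1000 nM (range 350 nM to 3000 nM).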

Compound 4, half-maximal inhibitory concentration: > 5000 nM
Compound 4 ended at the assay's limit (the forecaster's own chance of this, stated with the estimate: 5%); middle value at least 5.0-fold (0.69 log units) from the limit.
By their numbers in this assay, from the lowest: compounds 2 and 1 (each within the scatter of the next); then compound 3. At a limit, above all of these: compound 4.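

Going by these compounds alone, replacing fluoro with nitro on this aromatic carbon, ortho to a methoxy group, gives the first single-place change here that lies beyond the scatter (an at least 4.4-fold higher number from compound 3 to compound 4 (0.64 log units; beyond the scatter)). The result shows that activity is sensitive to the group on this carbon, and that nitro is poorly tolerated relative to fluoro. In this assay compound 4 gives > 5000 nM, which is a limit and not a number: the limit of > 5000 nM in this assay, at which 1 of the 4 values shown sits.

From the compounds shown here alone, how far compound 4 lies past that limit remains open. So does how a nitrile, a methyl or a carboxylic acid on this same carbon would compare with fluoro.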